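The source may report more compounds than this note shows. Statements on the series, on what has been measured and on what is new or still open speak of the compounds shown alone.

Compound 1, `CCCCCCCCCCCCCOC(=O)NC(=O)Oc1c(C(C)C)cccc1C(C)C`: 9 nM
Compound 2, `CCCCCCCCC(C)OC(=O)NC(=O)Oc1c(C(C)C)cccc1C(C)C`: 270 nM

In an assay on microsomes from intestine for inhibition of acyl-CoA:cholesterol acyltransferase (Oryctolagus cuniculus) (a lower number here means a stronger inhibitor, a higher number a weaker inhibitor), compound 1 gives 9 nM, while compound 2 gives 270 nM, the higher of the two numbers, with a gap to compound 1 that lies beyond the scatter. Compound 3, `CCCCCCCCCCCCC(C)OC(=O)NC(=O)Oc1c(C(C)C)cccc1C(C)C`, differs from compound 2 in one place: butyl in place of hydrogen on a saturated chain carbon, nine bonds along the chain from an oxygen next to a carbonyl group. This makes the chain of compound 3 closer in length to that of compound 1, although it keeps a branch that compound 1 lacks. The expected step is a 4.5-fold lower number from compound 2 to compound 3 (0.65 log units; beyond the scatter), toward a lower number. Compound 3 is estimated at 60 nM, within a range from 15 nM to 250 nM.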

Compound 3, half-maximal inhibitory concentration: 17 nM
Compound 3: the middle estimate sits 3.5-fold (0.55 log units) above what was measured; the measured number falls inside the stated range.
By their numbers in this assay, from the lowest: compounds 1 and 3 (each within the scatter of the next); then compound 2.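

In this assay, butyl in place of hydrogen at this chain carbon gives a 16-fold lower number from compound 2 to compound 3 (1.20 log units; beyond the scatter) and so shows that chain length here can strongly change the number. Methyl in place of hydrogen on the saturated chain carbon bound to the oxygen gives a 1.9-fold higher number from compound 1 to compound 3 (0.28 log units; within the scatter) and so leaves no clear effect of this branch once the chain is long. No measurement available here explains either result. From the compounds shown here alone, whether a longer chain would go on lowering the number remains open. So does the outcome with a phenyl ring or an amine in place of butyl.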